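The source may hold more compounds than are shown below. What is called first, only, known or untested is meant among the compounds shown, and "the series" means these compounds.

In a functional assay on KB cells (Homo sapiens) for antiproliferative activity, read by sulforhodamine B assay, with a stated time of 3 days (a lower number here means a stronger inhibitor of growth, a higher number a weaker inhibitor of growth), compound 1 `O=C(Nc1cccc(Nc2ncc(F)c(Nc3ccc(F)cc3)n2)c1)c1ccccc1` gives > 10000 nM, a limit of the assay and not a number. Going by the values given here, compound 2 `O=C(Nc1cc(Cl)cc(Cl)c1)c1cccc(Nc2ncc(F)c(Nc3ccc(F)cc3)n2)c1` gives 20100 nM, the only actual number so far. Compound 3 `Cn1ccnc1NC(=O)c1cccc(Nc2ncc(F)c(Nc3ccc(F)cc3)n2)c1` differs from compound 2 in one group: 1-methyl-1H-imidazol-2-yl in place of 3,5-dichlorophenyl on an amide-type nitrogen. Among the compounds with values here, the only measured step, a step that the limit leaves unreadable from compound 1 to compound 2, has no readable size, as the limit of > 10000 nM in this assay, at which 1 of the 2 values shown sits, shows, so it offers neither a size nor a direction for this change. No move beyond the scatter is expected, and the estimated step runs a 1.0-fold lower number from compound 2 to compound 3 (0.00 log units; within the scatter). Compound 3 is expected at 20000 nM, with an estimated range of 7000 nM to 50000 nM.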

Compound 3, concentration for 50% growth inhibition: 14600 nM
Beside the measured number, compound 3's estimate is 1.4-fold (0.14 log units) above it, and the stated range covers the measured number.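

In this assay, going by these compounds alone, the first readable step is a 1.4-fold lower number from compound 2 to compound 3 (0.14 log units; within the scatter) and it comes with 1-methyl-1H-imidazol-2-yl in place of 3,5-dichlorophenyl on an amide-type nitrogen. At this place, the two rings are not told apart, although the entering group has 2 hydrogen-bond acceptors and the leaving group has 0. The steps from compound 1 cannot be read because of a limit of the assay: the limit of > 10000 nM in this assay, at which 1 of the 3 values shown sits.

On these data alone, whether a piperidine or a carboxylic acid on this nitrogen would give a step beyond the scatter remains open.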